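The compounds below may be only part of what the source reports. "The series", "measured", "known", "first", "only" and "open" are said of these compounds alone.

Working notes on the series. The shared core of compound 1 `Cc1nn(-c2ncnc3nc[nH]c23)c2c1C(C(=O)Nc1ccccc1)CC(=O)N2` carries a phenylcarbamoyl group on the saturated ring carbon. Among the measured compounds shown here, in a functional assay on HEK293 cells for agonist activity at G-protein coupled receptor 39 (Homo sapiens), read by scintillation proximity assay and inositol phosphate accumulation, with a stated time of 75 min, in the presence of a further agent that is not named here (on this read-out lower numbers stand for an effect already at smaller amounts and higher numbers for an effect only at larger amounts of compound), compound 1 gives 10 nM, the second highest of the three numbers known so far. For the measured compounds named here, compound 2 `Cc1nn(-c2ncnc3nc[nH]c23)c2c1C(C(=O)NCc1ccc(F)cc1)CC(=O)N2` gives 4 nM, and the step of a 2.5-fold lower number from compound 1 to compound 2 (0.40 log units; beyond the scatter) is the one measured change at that position. Going by the values given here, compound 3 `C/C(=N\NC(=O)c1cc2ccccc2cc1O)c1ccc(N)cc1`, built on a different scaffold, gives 1100 nM; no single-point step links it to compound 1, so the two values are simply noted side by side.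

Compound 4 `CCCCCCCCOC1CC(=O)Nc2c1c(C)nn2-c1ncnc2nc[nH]c12` is the next analogue: octyloxy in place of phenylcarbamoyl on a saturated ring carbon. Among the compounds with values here, only the step from compound 1 to compound 2 bears on this position, and it kept the carbamoyl unit while swapping the group on its nitrogen; here the whole phenylcarbamoyl leaves and octyloxy enters, a change with no measured precedent. Compound 4 is therefore expected to sit higher, a 10-fold higher number from compound 1 to compound 4 (1.00 log units; beyond the scatter), with wide uncertainty. The estimate for compound 4 is 100 nM, within 15 nM to 1000 nM.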

Compound 4, half-maximal effective concentration: 8 nM
Compound 4: the middle estimate sits 13-fold (1.10 log units) above what was measured; measured number outside the range, below it.
By their numbers in this assay, from the lowest: compounds 2, 4 and 1 (each within the scatter of the next, the first and the last beyond it); then compound 3.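

In this assay the exchange of phenylcarbamoyl for octyloxy on the saturated ring carbon gives a 1.3-fold lower number from compound 1 to compound 4 (0.10 log units; within the scatter) and leaves the two numbers indistinguishable. The earlier step changed only the group on the amide nitrogen, whereas this pair shows that the whole carbamoyl unit, its aromatic ring and the amide hydrogen can leave together and an open chain with the same count of heavy atoms can take their place without a change beyond the scatter. Among the compounds shown here, nothing measured so far accounts for this match between two such different groups.

Open, going by these compounds, is how the number responds at this carbon to a shorter chain such as butoxy, a longer chain such as dodecyloxy, an amine or a carboxylic acid. Also open, on these data alone, is whether the ether oxygen of octyloxy matters, a question that a plain nonyl chain on the same carbon would address.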